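Replacing the sugar on the ring nitrogen of compound 1

The compounds below may be only part of what the source reports. "The series", "measured", "known", "first", "only" and "open" are said of these compounds alone.

In a functional assay on HepG2 cells (Homo sapiens) for cytotoxicity, read by sulforhodamine B assay, with a stated time of 48 h (a lower number here means a stronger inhibitor, a higher number a weaker inhibitor), compound 1 (`N#Cc1c(-c2ccc(Cl)cc2)cc(-c2ccc(Cl)cc2)n([C@@H]2O[C@H](CO)[C@@H](O)[C@H]2O)c1=O`) gives 6.9 ug/mL, the lowest of the three numbers measured. Compound 2 (`C=CCn1c(-c2ccc(Cl)cc2)cc(-c2ccc(Cl)cc2)c(C#N)c1=O`) gives 20 ug/mL and compound 3 (`N#Cc1c(-c2ccc(Cl)cc2)cc(-c2ccc(Cl)cc2)n([C@@H]2O[C@H](CO)[C@@H](O)[C@H](O)[C@H]2O)c1=O`) gives 16.1 ug/mL. The step of a 2.9-fold higher number from compound 1 to compound 2 (0.46 log units; beyond the scatter) and the step of a 2.3-fold higher number from compound 1 to compound 3 (0.37 log units; beyond the scatter) both move away from compound 1, while a 1.2-fold lower number from compound 2 to compound 3 (0.09 log units; within the scatter) shows that the two replacements end close to each other.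

Compound 4 (`N#Cc1c(-c2ccc(Cl)cc2)cc(-c2ccc(Cl)cc2)n(CC(O)CCl)c1=O`) differs from compound 1 in this way: 3-chloro-2-hydroxypropyl in place of 3,4-dihydroxy-5-(hydroxymethyl)oxolan-2-yl on an aromatic nitrogen. Of the measured steps, a 2.9-fold higher number from compound 1 to compound 2 (0.46 log units; beyond the scatter) bears most directly on it, since there too an open chain takes the place of the 3,4-dihydroxy-5-(hydroxymethyl)oxolan-2-yl group on the aromatic nitrogen; a 2.3-fold higher number from compound 1 to compound 3 (0.37 log units; beyond the scatter) points the same way. A modest step towards a higher number is therefore expected for compound 4, namely a 2.2-fold higher number from compound 1 to compound 4 (0.34 log units; beyond the scatter). The estimate for compound 4 in this assay is 15 ug/mL, with an expected range from 7 ug/mL to 35 ug/mL.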

Compound 4, half-maximal inhibitory concentration: 4.8 ug/mL
Estimate against measurement, compound 4: 3.1-fold (0.49 log units) above; the measured number lies below the stated range.
By their numbers in this assay, from the lowest: compounds 4 and 1 (each within the scatter of the next); then compounds 3 and 2 (each within the scatter of the next).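

Compound 4 shows that, in this assay, the sugar ring on the aromatic nitrogen can give way to an open chain without a step beyond the scatter (a 1.4-fold lower number from compound 1 to compound 4 (0.16 log units; within the scatter)). An open chain as such therefore does not account for the higher number of the allyl compound, since the 3-chloro-2-hydroxypropyl chain stands clearly apart from it (a 4.2-fold lower number from compound 2 to compound 4 (0.62 log units; beyond the scatter)). The new chain also stands clearly apart from the six-membered sugar (a 3.4-fold lower number from compound 3 to compound 4 (0.53 log units; beyond the scatter)), so among these four compounds the division does not run between rings and chains, with compound 3 on the same side as compound 2 and compound 1 on the same side as compound 4.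

As far as these compounds go, whether the chlorine or the hydroxyl of the chain carries the step from the allyl group stays open, as does what an amine, a carboxylic acid or a longer chain would give at this position. Nothing measured here explains these differences.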